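The compounds below may be only part of what the source reports. "The series", "measured", "known", "first", "only" and "open" are said of these compounds alone.

In a functional assay on MCF7 cells (Homo sapiens) for inhibition, read by MTT assay, with a stated time of 96 h (a lower number here means a stronger inhibitor, a higher number a weaker inhibitor), compound 1 (`COc1ccc(Cc2c(Cc3cc(OC)c(O)c(OC)c3)nc(NC3=NC(=O)N(C)C3=O)n2C)cc1`) gives 29900 nM and compound 2 (`COc1ccc(Cc2nc(N)n(C)c2Cc2ccc(OC)cc2)cc1`) gives 28800 nM. These two numbers lie within the usual scatter of repeated measurements, so compound 2 stands level with compound 1 and neither can be ranked above the other. Compound 3 (`COc1ccc(Cc2c(C(OC)c3ccc(OC)cc3)nc(N)n2C)cc1`) keeps everything in compound 2 except one place: methoxy in place of hydrogen on a saturated chain carbon bound to two aromatic carbons. In words, this puts methoxy in place of hydrogen on a saturated chain carbon bound to two aromatic carbons. For the measured compounds named here, no pair of measured compounds shows what such a change does, so no shift beyond the scatter is expected in this assay, and no direction can be favoured. The estimated step, a 1.0-fold higher number from compound 2 to compound 3 (0.02 log units; within the scatter), is accordingly small. For compound 3 the estimated value is 30000 nM, with an expected range from 12000 nM to 70000 nM.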

Compound 3, half-maximal inhibitory concentration: 22700 nM
For compound 3 the middle estimate is 1.3-fold (0.12 log units) above the measured one, within the range that was stated.
By their numbers in this assay, from the lowest: compounds 3, 2 and 1 (each within the scatter of the next).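

In this assay the step is a 1.3-fold lower number from compound 2 to compound 3 (0.10 log units; within the scatter) and it comes from methoxy in place of hydrogen on a saturated chain carbon bound to two aromatic carbons. For the compounds shown here, this is the first measured pair that differs in only one place, so it gives the first direct reading of a change at this position. It shows that this carbon can carry methoxy with no shift that stands out from the scatter of repeated measurements. No supporting data bear on this result.

As far as these compounds go, it remains open whether another group on this same carbon, such as hydroxyl, an amine or a longer chain, would also stay within the scatter or would move the number. From the compounds shown here alone, it is also open whether methoxy at this carbon would give the same result on compound 1.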